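The source may hold more compounds than are shown below. What is called first, only, known or untested is meant among the compounds shown, and "the series" means these compounds.

Measured compounds:
compound 1 `COc1ccc(-c2cc(/C=C/C(=O)c3ccc(N)cc3)[nH]n2)cc1`, in a functional assay on T47D cells (Homo sapiens) for inhibition, read by sulforhodamine B assay, with a stated time of 48 h; a lower number here means a stronger inhibitor of growth, a higher number a weaker inhibitor of growth: 1470 nM
compound 2 `COc1cc(-c2cc(/C=C/C(=O)c3ccc(Cl)c(Cl)c3)[nH]n2)cc(OC)c1OC`, in this assay: 1660 nM

The two numbers lie within the usual scatter of each other, so compound 2 stands alongside compound 1 rather than apart from it. Compound 3 `COc1ccc(C(=O)/C=C/c2cc(-c3cc(OC)c(OC)c(OC)c3)n[nH]2)cc1` differs from compound 2 by 4-methoxyphenyl in place of 3,4-dichlorophenyl on a carbonyl carbon. Among the compounds with values here, no measured pair shows this same change, so there is no step to lean on. In this assay the change is expected to move the number little, with no clear direction, and the expected step is a 1.1-fold higher number from compound 2 to compound 3 (0.04 log units; within the scatter). Compound 3 is therefore estimated at 1800 nM, within 600 nM to 6000 nM.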

Compound 3, concentration for 50% growth inhibition: 2310 nM
For compound 3 the middle estimate is 1.3-fold (0.11 log units) below the measured one; low and high end bracket the measured number.
By their numbers in this assay, from the lowest: compounds 1, 2 and 3 (each within the scatter of the next).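

Within the data shown here, this is the first measured pair in this assay that differs in only one place: with 4-methoxyphenyl in place of 3,4-dichlorophenyl on a carbonyl carbon, the result is a 1.4-fold higher number from compound 2 to compound 3 (0.14 log units; within the scatter), so this assay does not separate the two groups. At this position, then, two chlorine atoms and one oxygen-bearing methoxy group are tolerated alike in the trimethoxy-bearing core of compound 2. Nothing available explains this result. As far as these compounds go, whether a carboxylic acid or a trifluoromethyl group on the phenyl ring at this carbonyl carbon would also leave the number within the scatter stays open.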